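The source may hold more compounds than are shown below. What is called first, only, known or untested is meant among the compounds shown, and "the series" means these compounds.

Working notes on the series. Compound 1 `CCc1nn(C)c(CO/N=C/c2c(C)nn(C)c2Oc2ccc(F)cc2)c1Cl` is measured in a functional assay on SMMC-7721 cells (Homo sapiens) for inhibition, read by MTT assay, with a stated time of 72 h, tested at 25 uM (on this read-out lower numbers stand for less inhibition and higher numbers for more inhibition at the one concentration tested (going by the name of the read-out)), only as a limit of the assay, < 80%, with no number attached. Compound 2 `Cc1nn(C)c(Oc2ccc(F)cc2)c1/C=N\OCc1c(Cl)c(-c2ccc(F)cc2)nn1C` gives 80% in this assay. The evidence on the one limit is thin: the limit of < 80% in this assay, at which 1 of the 2 values shown sits. Compound 3 `CCc1nn(C)c(CO/N=C/c2c(C)nn(C)c2Oc2ccccc2F)c1Cl` differs from compound 1 by 2-fluorophenyl in place of 4-fluorophenyl on an oxygen on an aromatic ring. Among the measured compounds shown here, with no measured step to lean on, the step from compound 1 to compound 3 is expected to stay within the scatter, a step that the limit leaves unreadable from compound 1 to compound 3. Compound 3 is therefore estimated at 50%, most likely again reported only as a limit, with a range from 10% to 79%.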

Compound 3, a percentage reported as inhibition, at one concentration (the size of the read-out at that concentration, not a potency): < 80%
Compound 3 gave a limit, no number (the forecaster's own chance of this, stated with the estimate: 70%); the middle value does not contradict the limit.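

No step can be read between compound 1 and compound 3, since in this assay both stand only as limits: the limit of < 80% in this assay, at which 2 of the 3 values shown sit. As far as these compounds go, whether 2-fluorophenyl and 4-fluorophenyl differ in inhibition here remains open.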